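The compounds below may be only part of what the source reports. "The series", "measured", "known", "first", "only" and "open" are said of these compounds alone.

Compounds measured so far:
compound 1 `O=C(O)CCCOc1ccc(-c2cccc(Oc3ccccc3)c2)cc1` — 6800 nM
compound 2 `O=C(O)CCCOc1ccc(-c2cc(Oc3ccccc3)ccc2F)cc1` — 3590 nM

In a functional assay on isolated protein for agonist activity at Free fatty acid receptor 1 (Homo sapiens), read by HTRF and inositol phosphate accumulation, with a stated time of 60 min (on this read-out lower numbers stand for an effect already at smaller amounts and higher numbers for an effect only at larger amounts of compound), compound 1 gives 6800 nM, the larger of the two numbers shown, and compound 2 gives 3590 nM; the step of a 1.9-fold lower number from compound 1 to compound 2 (0.28 log units; within the scatter) stays within the scatter. Compound 3 `COc1cccc(Oc2cccc(-c3ccc(OCCCC(=O)O)cc3)c2)c1` differs from compound 1 by methoxy in place of hydrogen on an aromatic carbon. Among the measured compounds shown here, no measured step involves a methoxy group; the only one available, a 1.9-fold lower number from compound 1 to compound 2 (0.28 log units; within the scatter), concerns a different change on a different ring and is itself within the scatter, so for compound 3 no step beyond the scatter is expected, a 1.4-fold lower number from compound 1 to compound 3 (0.13 log units; within the scatter). The estimate for compound 3 is 5000 nM, with a range from 1500 nM to 16000 nM.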

Compound 3, half-maximal effective concentration: 6310 nM
Compound 3: the middle estimate sits 1.3-fold (0.10 log units) below what was measured; measured number inside the range.
By their numbers in this assay, from the lowest: compounds 2, 3 and 1 (each within the scatter of the next).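

In this assay, 3-methoxyphenoxy in place of phenoxy gives a 1.1-fold lower number from compound 1 to compound 3 (0.03 log units; within the scatter), so adding methoxy at this position, on a ring the fluoro step did not touch, produces no step beyond the scatter. No measurement shown here bears on the reason for this result.

The compounds shown leave open whether an amine, a hydroxyl group or trifluoromethyl at this same place would give a step beyond the scatter. They also leave open how methoxy would read on the other carbons of this ring.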